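Swapping the aminophenyl for a dichlorophenyl on the shared chalcone core

A few compounds are considered here, and "the series" means these few. Any claim that something is new, unique, unknown or untested is made for them only; others in the source may bear on it.

Measured so far:
- compound 1 `COc1ccc(-c2cc(/C=C/C(=O)c3ccc(N)cc3)[nH]n2)cc1`: -58%
- compound 2 `COc1cc(-c2cc(/C=C/C(=O)c3ccc(N)cc3)[nH]n2)cc(OC)c1OC`: -40%

Both compounds were tested in a functional assay on SW-620 cells (Homo sapiens) for cytotoxicity, read by sulforhodamine B assay, with a stated time of 48 h, tested at 100 uM; a higher number here means a weaker effect of the compound at the concentration tested, a lower number a stronger effect. Compound 1 gives -58%, and compound 2 gives -40%. Of the two numbers, compound 2 stands at the higher, weaker end, and the gap to compound 1 lies beyond the usual scatter, so compound 2 is the less active of the pair under these conditions.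

Compound 3 `COc1cc(-c2cc(/C=C/C(=O)c3ccc(Cl)c(Cl)c3)[nH]n2)cc(OC)c1OC` keeps the trimethoxyphenyl end of compound 2 and differs only at the carbonyl carbon: 3,4-dichlorophenyl in place of 4-aminophenyl on a carbonyl carbon. Among the measured compounds shown here, no measured pair in this set shows what such an exchange does in this assay, so there is no step to lean on.

For compound 3 a step of a number 5 percentage points higher from compound 2 to compound 3 (within the scatter) is expected, that is, no shift beyond the scatter in either direction. On that basis compound 3 is estimated at -35%, with a plausible range from -75% to 5%, the wide span reflecting how little the two measured compounds say about this particular exchange.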

Compound 3, a percentage reported as activity, at one concentration (the size of the read-out at that concentration, not a potency): -5%
Estimate against measurement, compound 3: 30 percentage points below; measured number inside the range.
By their numbers in this assay, from the lowest: compound 1; then compound 2; then compound 3.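

In this assay, the group on the carbonyl carbon proves to matter: 3,4-dichlorophenyl in place of 4-aminophenyl gives a number 35 percentage points higher from compound 2 to compound 3 (beyond the scatter), so the effect at the concentration tested is clearly weaker. Among the compounds shown here, this is the first change in the set made in one place only, and it shows that this end of the molecule is not a neutral spot where one aryl group can stand in for another without consequence. The exchange alters several things at once, removing the amino group with its hydrogen-bond donor and acceptor and adding two chlorines, and nothing measured here explains the size of the step.

The compounds shown leave open whether the loss follows from removing the amino group or from adding the chlorines, a question that an unsubstituted phenyl or a monochlorophenyl at this position could help to separate. They also leave open whether the same exchange would produce a similar step on compound 1, which carries a different group at the other end of the shared core.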